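Furan-3-yl for Thiophen-2-yl: Two Pairs, One Limit

The source may hold more compounds than are shown below. What is called first, only, known or untested is meant among the compounds shown, and "the series" means these compounds.

Three compounds have been measured in a functional assay on CEM-DNR-bulk cells (Homo sapiens), read by MTT assay, with a stated time of 72 h (on this read-out higher numbers stand for weaker inhibition and lower numbers for stronger inhibition), and every result is a limit of the assay rather than a number:

Compound 1 `Cc1ncnc2c1c(-c1ccoc1)cn2[C@@H]1O[C@H](CO)[C@@H](O)[C@H]1O`: > 20000 nM
Compound 2 `Cc1ncnc2c1c(-c1cccs1)cn2[C@@H]1O[C@H](CO)[C@@H](O)[C@H]1O`: > 20000 nM
Compound 3 `Nc1nc(N)c2c(-c3cccs3)cn([C@@H]3O[C@H](CO)[C@@H](O)[C@H]3O)c2n1`: > 20000 nM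

The change from compound 2 to compound 1 is furan-3-yl in place of thiophen-2-yl on an aromatic carbon. Its step that the two limits leave unreadable from compound 2 to compound 1 cannot be sized because both values sit at the limit of > 20000 nM in this assay, at which 3 of the 3 values shown sit. How the core of compound 3 differs from the core of compound 2 is not broken down here.

Compound 4 `Nc1nc(N)c2c(-c3ccoc3)cn([C@@H]3O[C@H](CO)[C@@H](O)[C@H]3O)c2n1` is not yet measured. It differs from compound 3 by furan-3-yl in place of thiophen-2-yl on an aromatic carbon, the same change as between compound 2 and compound 1, at a place described in the same words. For compound 4 the expected result in this assay is 30000 nM, an estimated step that the limit leaves unreadable from compound 3 to compound 4. That expectation rests on the step that the two limits leave unreadable from compound 2 to compound 1, which gave no readable movement when the same change was made.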

Compound 4, half-maximal inhibitory concentration: > 20000 nM
Compound 4: no number, only a limit; the forecaster's own chance of this, stated with the estimate: 90%; the middle value lies beyond the limit too.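

No step can be read between compound 3 and compound 4, because both results are limits rather than numbers: the limit of > 20000 nM in this assay, at which 4 of the 4 values shown sit.

The compounds shown leave open whether furan-3-yl and thiophen-2-yl differ at all in strength of inhibition on either core.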